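The compounds below may be only part of what the source reports. "The series", "measured", "known", "first", "only" and "open" are said of these compounds alone.

Compound 3 `CCCCNc1nc(N)nc2c1CCN(C)C2` is measured in an assay on HEK293 cells for agonist activity at Toll-like receptor 8 (Homo sapiens), read by a luciferase reporter, with a stated time of 6 h (on this read-out higher numbers stand for an effect only at larger amounts of compound and lower numbers for an effect already at smaller amounts), where compound 3 gives 0.2 uM. Among the three compounds with numbers, compound 3 stands second highest. Compound 2 `CCCCNc1nc(N)nc2c1CCNC2` gives 0.6 uM, while compound 1 `CCCCNc1nc(N)nc2c1CN(Cc1ccccc1)CC2` gives 0.06 uM. Going by the values given here, the one measured step that touches the same ring nitrogen is a 3.0-fold lower number from compound 2 to compound 3 (0.48 log units; beyond the scatter), a modest change for a small group. Compound 4 `CCCCNc1nc(N)nc2c1CCN(C(=O)c1ccccc1)C2` differs from compound 3 in one place: benzoyl in place of methyl on an amine nitrogen in a ring. Compound 1, whose values show the lowest number here, also carries a larger group on that nitrogen, so a further lowering is expected, though with much uncertainty. The step from compound 3 to compound 4 is therefore estimated as a 1.3-fold lower number from compound 3 to compound 4 (0.12 log units; within the scatter). For compound 4 the expected value is 0.15 uM, within a range from 0.04 uM to 0.6 uM.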

Compound 4, minimum effective concentration: 0.8 uM
Compound 4: middle estimate off by 5.3-fold (0.73 log units), on the low side; measured number outside the range, above it.
By their numbers in this assay, from the lowest: compound 1; then compound 3; then compounds 2 and 4 (each within the scatter of the next).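

In this assay a larger group on this ring nitrogen does not by itself bring a lower number: benzoyl in place of methyl gives a higher one (a 4.0-fold higher number from compound 3 to compound 4 (0.60 log units; beyond the scatter)), and benzoyl in place of hydrogen stays within the scatter (a 1.3-fold higher number from compound 2 to compound 4 (0.12 log units; within the scatter)). Of the three groups compared at this nitrogen, only methyl stands apart from hydrogen. Nothing measured here explains this difference. Still open, from the compounds shown here alone, is how a benzyl or ethyl group would read on this same nitrogen of the core of compound 3.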